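Swapping Thiophene for Furan on a Pair with Low Numbers

A few compounds are considered here, and "the series" means these few. Any claim that something is new, unique, unknown or untested is made for them only; others in the source may bear on it.

Compound 1, `CC(C)OC(=O)C1=C(C(F)(F)F)NC(=O)NC1c1ccsc1`, was tested in an assay on HeLa cells for displacement of a labelled ligand from adenosine receptor A3 (Homo sapiens), read by radioligand binding, with a stated time of 180 min, tested at 1 uM (a higher number here means more inhibition at the concentration tested (going by the name of the read-out), a lower number less inhibition), where compound 1 gives 3%. Within the data shown here, only one other compound was measured beside it: compound 2, `CC1=C(C(=O)OC(C(F)(F)F)C(F)(F)F)C(c2ccoc2)NC(=O)N1`, which in this assay gives 1%. These two numbers lie within the usual scatter of each other, so neither compound can be called the stronger; both sit near the floor of the scale, where the read-out hardly distinguishes a compound from one that does nothing. Compound 2 also differs from compound 1 in several places at once, so no single change can be read off between them.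

Compound 3, `CC(C)OC(=O)C1=C(C(F)(F)F)NC(=O)NC1c1ccoc1`, has not yet been measured. It differs from compound 1 in one place: furan-3-yl in place of thiophen-3-yl on a saturated ring carbon. Among the measured compounds shown here, no measured pair shows what this change does. Because compound 1 gives 3% and compound 2 gives 1%, both essentially at the bottom of the scale, the step of no change at the digits printed from compound 1 to compound 3 (within the scatter) is expected to be none beyond the scatter. Compound 3 is therefore estimated to give 3% in this assay, within a range from -6% to 13%.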

Compound 3, a percentage reported as inhibition, at one concentration (the size of the read-out at that concentration, not a potency): 1%
Beside the measured number, compound 3's estimate is 2 percentage points above it; the range from low to high includes it.
By their numbers in this assay, from the lowest: compounds 2, 3 and 1 (each within the scatter of the next).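

Among these compounds, this is the first pair that differs in one place only, so the change from thiophen-3-yl to furan-3-yl on the saturated ring carbon can now be read directly: in this assay the result is a number 2 percentage points lower from compound 1 to compound 3 (within the scatter). With the rest of compound 1 kept as it is, the read-out therefore cannot tell the two rings apart. Among the compounds shown here, both compounds sit near the floor of the scale, however, so the pair shows only that neither ring gives more than a trace of inhibition at the concentration tested, not that the two rings would be interchangeable in a compound with a clearly higher number, and no measurement at hand bears on why the number stays so low.

Going by these compounds, it remains open whether any group on this saturated ring carbon, such as a phenyl ring or a cyclohexyl ring, would lift the number clear of the floor. On these data alone, it is equally open whether replacing the trifluoromethyl group with an ethyl group, or the isopropoxycarbonyl group with a carboxylic acid, would do so, and whether the thiophene and furan rings would still match on such a compound.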